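Swapping the ester promoiety: a stability check

A few compounds are considered here, and "the series" means these few. Any claim that something is new, unique, unknown or untested is made for them only; others in the source may bear on it.

Compound 1, `C[C@@H](O)[C@H]1C(=O)N2C(C(=O)OCC(F)(F)F)=C(S[C@@H]3CN[C@H](C(=O)Nc4cccc(C(=O)O)c4)C3)[C@H](C)[C@H]12`, in a physicochemical assay for metabolic stability, read by LC-MS, in phosphate buffer, with a stated time of 3 h, at pH 7.4, tested at 50 uM (on this read-out lower numbers stand for a less stable compound and higher numbers for a more stable compound), gives > 95%, which is a limit of the assay rather than a number.
Compound 2, `CCC(CC)C(=O)OCOC(=O)C1=C(S[C@@H]2CN[C@H](C(=O)Nc3cccc(C(=O)O)c3)C2)[C@H](C)[C@@H]2[C@@H]([C@@H](C)O)C(=O)N12`, gives in this assay > 95%, again a limit of the assay.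

Among the measured compounds shown here, compound 2 therefore stands at the limit, as does the only other measured compound (the limit of > 95% in this assay, at which 2 of the 2 values shown sit). Compound 3, `COC(=O)OCOC(=O)C1=C(S[C@@H]2CN[C@H](C(=O)Nc3cccc(C(=O)O)c3)C2)[C@H](C)[C@@H]2[C@@H]([C@@H](C)O)C(=O)N12`, differs from compound 2 by methoxy in place of pentan-3-yl on a carbonyl carbon. For the measured compounds named here, the one measured step, a step that the two limits leave unreadable from compound 1 to compound 2, cannot show whether changing this ester end moves the read-out in either direction, so it gives no size and no direction to carry over. What the two measurements do show is that neither variant of this ester end lost material within the run. Compound 3 is therefore expected to sit in the same region, with an expected step of a number no higher from compound 2 to compound 3 (the limit leaves the size open) that amounts to none beyond the scatter. For compound 3 the estimate is 95%, ranging from 85% to 100%.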

Compound 3, percent of the compound remaining: > 95%
Compound 3: no number, only a limit (the forecaster's own chance of this, stated with the estimate: 70%); the middle value sits exactly at the limit.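

Compound 3 also reaches a limit of the assay rather than a number, so no step among compound 1, compound 2 and compound 3 can be read: the limit of > 95% in this assay, at which 3 of the 3 values shown sit.

The compounds shown leave open whether these three ester ends differ at all in this assay.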